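The source may hold more compounds than are shown below. What is called first, only, known or untested is meant among the compounds shown, and "the series" means these compounds.

Measured so far:
compound 1 `COCC1CCN(c2c(S(=O)(=O)c3cccc(C#N)c3)cnc3cc(F)ccc23)CC1` with 91% in an assay on isolated protein for displacement of a labelled ligand from metabotropic glutamate receptor 5 (Homo sapiens), with a stated time of 60 min, tested at 1 uM; a higher number here means more inhibition at the concentration tested (going by the name of the read-out), a lower number less inhibition
compound 2 `COc1cccc(S(=O)(=O)c2cnc3cc(F)ccc3c2N2CCC(C)CC2)c1` with 90% in this assay
compound 3 `Cc1ccc(S(=O)(=O)c2cnc3cc(F)ccc3c2N2CCC(C)CC2)cc1C` with 90% in this assay

Compound 3 stands level with compound 2 at the digits shown, the two together the lowest of the three numbers, while compound 1 lies a single percentage point higher, a gap that is within the scatter. For the measured compounds named here, the one step that has been measured, no change at the digits printed from compound 2 to compound 3 (within the scatter), carries a change on the sulfonyl sulfur and leaves the read-out unchanged within the scatter.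

Compound 4 `CC1CCN(c2c(S(=O)(=O)c3cccc(C#N)c3)cnc3cc(F)ccc23)CC1` has not yet been measured. It differs from compound 3 by 3-cyanophenyl in place of 3,4-dimethylphenyl on a sulfonyl sulfur. This is again a change of the group on the sulfonyl sulfur, the same place touched by the measured step, which was flat. Compound 1 also carries a 3-cyanophenyl and gives 91%, a number at the same high level. Compound 4 is therefore expected to show no step beyond the scatter, no change at the digits printed from compound 3 to compound 4 (within the scatter). The estimate for compound 4 is 90%, with a range from 81% to 97%.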

Compound 4, a percentage reported as inhibition, at one concentration (the size of the read-out at that concentration, not a potency): 92%
Compound 4: middle estimate off by 2 percentage points, on the low side; the range from low to high includes it.
By their numbers in this assay, from the lowest: compounds 2, 3, 1 and 4 (each within the scatter of the next).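

In this assay, 3-cyanophenyl in place of 3,4-dimethylphenyl on the sulfonyl sulfur gives a number 2 percentage points higher from compound 3 to compound 4 (within the scatter) and cyano in place of methoxy on an aromatic carbon gives a number 2 percentage points higher from compound 2 to compound 4 (within the scatter), so the group carrying the nitrile reads level with both of the other groups at this place. For the compounds shown here, a second place is read for the first time: hydrogen in place of methoxy on a saturated chain carbon bound to a saturated ring carbon gives a number 1 percentage points higher from compound 1 to compound 4 (within the scatter) and leaves the read-out level there too. Nothing measured accounts for these flat steps.

All four compounds lie within the scatter at a single concentration, which leaves their order open. Also open, as far as these compounds go, is whether a carboxylic acid in place of the cyano, or a longer chain in place of that hydrogen, would hold the number at this level.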